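The source may report more compounds than this note shows. Statements on the series, on what has been measured and on what is new or still open speak of the compounds shown alone.

Compound 1 `Cc1ccc(-c2csc(N/N=C/c3ccc(Cl)cc3Cl)n2)cc1` and compound 2 `Cc1ccc(-c2csc(N/N=C/c3cccs3)n2)cc1` share one core. In a functional assay, read by spectrophotometry, with a stated time of 15 min, tested at 100 ug/mL (on this read-out higher numbers stand for a stronger effect at the one concentration tested and lower numbers for a weaker effect), compound 1 gives 85.3%, the lower of the two numbers, and compound 2 gives 91%; the two values lie within the scatter of each other, so no order between them can be drawn. Compound 3 `Clc1ccc(/C=N/Nc2nc(-c3ccccc3)cs2)c(Cl)c1` is not yet measured. It differs from compound 1 by hydrogen in place of methyl on an aromatic carbon. Among the compounds with values here, no measured step of this kind exists here, so compound 3 is expected to sit in this assay close to compound 1, with no step beyond the scatter in either direction. Compound 3 is estimated at 82%, in the range 65% to 95%. This estimate means a step of a number 3.3 percentage points lower from compound 1 to compound 3 (within the scatter).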

Compound 3, a percentage reported as inhibition, at one concentration (the size of the read-out at that concentration, not a potency): 87.4%
For compound 3 the middle estimate is 5.4 percentage points below the measured one; the range from low to high includes it.
By their numbers in this assay, from the lowest: compounds 1, 3 and 2 (each within the scatter of the next).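

In this assay, within the data shown here, the change from 4-methylphenyl to phenyl is a number 2.1 percentage points higher from compound 1 to compound 3 (within the scatter) and is the first step read at this position. The methyl on this aromatic carbon, para to a large group, thus gives way to hydrogen with the read-out staying within the scatter of compound 1. Nothing at hand bears on why this is so.

Open, as far as these compounds go, is whether another group at this place, such as an amine, a methoxy or a carboxylic acid, would give a step beyond the scatter. Also open, from the compounds shown here alone, is whether the same change would read alike with the thiophene-bearing side of compound 2.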